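Swapping the aryl group on the triazole of compound 2

The source may report more compounds than this note shows. Statements on the series, on what has been measured and on what is new or still open speak of the compounds shown alone.

Of the compounds shown here, two of a shared core have been measured in a functional assay on HT-29 cells (Homo sapiens) for cytotoxicity, read by MTT assay, with a stated time of 72 h; a higher number here means a weaker inhibitor, a lower number a stronger inhibitor. Compound 1, `COc1cc2c(Oc3ccc(NC(=O)c4nnn(-c5ccc(F)cc5)c4C(F)(F)F)cc3F)ccnc2cc1OCCCN1CCCCC1`, gives 150 nM. Compound 2, `COc1cc2c(Oc3ccc(NC(=O)c4nnn(-c5ccc(F)cc5)c4C(F)(F)F)cc3F)ccnc2cc1OCCCN1CCC(C)CC1`, gives 160 nM. Among the compounds with values here, the one step between them, a 1.1-fold higher number from compound 1 to compound 2 (0.03 log units; within the scatter), alters only the saturated ring at the end of the side chain, so compound 2 stands side by side with compound 1 and neither can be called the stronger.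

Compound 3, `COc1cc2c(Oc3ccc(NC(=O)c4nnn(-c5ccccc5C(F)(F)F)c4C(F)(F)F)cc3F)ccnc2cc1OCCCN1CCC(C)CC1`, is not yet measured. It differs from compound 2 by 2-(trifluoromethyl)phenyl in place of 4-fluorophenyl on an aromatic nitrogen. Within the data shown here, no measured step touches this part of the molecule: the only step known, a 1.1-fold higher number from compound 1 to compound 2 (0.03 log units; within the scatter), concerns a distant saturated ring and says nothing about the aryl group on the triazole nitrogen. The data therefore give no direction for this change, and the expectation can only rest on the value of compound 2 itself, with a wide range to allow for an unknown effect. In this assay compound 3 is estimated at 250 nM, between 70 nM and 900 nM, which would be a step of a 1.6-fold higher number from compound 2 to compound 3 (0.19 log units; within the scatter).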

Compound 3, half-maximal inhibitory concentration: 200 nM
The estimate for compound 3 lay 1.3-fold (0.10 log units) above the measured number, and the stated range covers the measured number.
By their numbers in this assay, from the lowest: compounds 1, 2 and 3 (each within the scatter of the next).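

In this assay, within the data shown here, putting 2-(trifluoromethyl)phenyl in place of 4-fluorophenyl on the aromatic nitrogen gives the first reading at this position (a 1.3-fold higher number from compound 2 to compound 3 (0.10 log units; within the scatter)), which the earlier step on the distant saturated ring could not supply. The two numbers stand within the scatter of each other, even though the entering group has 10 heavy atoms and the leaving group has 7 heavy atoms, so this position tolerates this particular swap without a readable difference in the assay. That is a statement about this one pair of groups and not a rule for the position, and nothing available here bears on why the two groups read alike.

Still open, going by these compounds, is whether a phenyl ring carrying an amine or a carboxylic acid, or a simple alkyl chain in place of the aryl ring on this nitrogen, would move the number beyond the scatter. Also open, on these data alone, is whether 2-(trifluoromethyl)phenyl would read the same with the unmethylated saturated ring of compound 1 at the end of the side chain.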